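The compounds below may be only part of what the source reports. "The series", "measured", "known", "first", "only" and "open" are said of these compounds alone.

Measured so far in a functional assay, read by spectrophotometry, with a stated time of 2 h, tested at 0.5 mg/mL; a higher number here means a stronger effect of the compound at the concentration tested, a lower number a weaker effect:
compound 1 `CC(C)[C@@H]1CC[C@@H](C)C[C@@]12N(C)C(=O)[C@@H]1[C@H]3C(=O)N(c4ccccc4)C(=O)[C@H]3ON12` gives 28.7%
compound 2 `Cc1cccc(N2C(=O)[C@H]3[C@H](ON4[C@@H]3C(=O)N(C)[C@@]43C[C@H](C)CC[C@H]3C(C)C)C2=O)c1` gives 25%

For the measured compounds named here, the two numbers sit within the scatter of each other; the one step so far, a number 3.7 percentage points lower from compound 1 to compound 2 (within the scatter), is a change of a hydrogen for a methyl on the aromatic ring carried by the ring amide nitrogen and shifts nothing beyond the noise. Compound 2 therefore stands with compound 1, not apart from it.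

Compound 3 `CC(C)[C@@H]1CC[C@@H](C)C[C@@]12N(C)C(=O)[C@@H]1[C@H]3C(=O)N(c4ccc5ccccc5c4)C(=O)[C@H]3ON12` differs from compound 2 by naphthalen-2-yl in place of 3-methylphenyl on an amide-type nitrogen in a ring. Going by the values given here, the only measured step that bears on it is the small one from compound 1 to compound 2, which touched the same aromatic ring but added only a methyl; no measured pair covers a second aromatic ring at this position. The expectation in this assay is thus a step of a number 1 percentage points higher from compound 2 to compound 3 (within the scatter) of no clear direction, with a wider range than the measured pair alone would suggest. Compound 3 is estimated at 26%, between 12% and 40%.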

Compound 3, a percentage reported as activity, at one concentration (the size of the read-out at that concentration, not a potency): 24.5%
For compound 3 the middle estimate is 1.5 percentage points above the measured one, within the range that was stated.
By their numbers in this assay, from the lowest: compounds 3, 2 and 1 (each within the scatter of the next).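

In this assay, naphthalen-2-yl in place of 3-methylphenyl on the amide-type nitrogen in a ring gives a number 0.5 percentage points lower from compound 2 to compound 3 (within the scatter) and naphthalen-2-yl in place of phenyl gives a number 4.2 percentage points lower from compound 1 to compound 3 (within the scatter). The earlier step covered only an added methyl, whereas these two add a second six-membered aromatic ring of carbon only, and the read-out still does not separate phenyl, 3-methylphenyl and naphthalen-2-yl at this position. No supporting data are available to account for this flat result.

On these data alone, all three groups on this nitrogen are aromatic groups of carbon only, so it remains open whether an amine, a carboxylic acid or a pyridyl ring there would move the read-out beyond the scatter. Also open, as far as these compounds go, is whether any change elsewhere on the shared core would do so.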